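Series notes: MCF7 cytotoxicity, step from compound 3 to compound 4

The source may report more compounds than this note shows. Statements on the series, on what has been measured and on what is new or still open speak of the compounds shown alone.

Measured so far:
compound 1 `COc1ccccc1/C=c1/[nH]c(=O)/c(=C\c2ccccc2OC)[nH]c1=O`: "not active" (no number reported)
compound 2 `C=CCn1c(=O)/c(=C\c2ccc(Cl)c(Cl)c2)[nH]c(=O)/c1=C\c1ccccc1`: "not active" (no number reported)
compound 3 `C=CCn1c(=O)/c(=C\c2cc(F)ccc2C)[nH]c(=O)/c1=C\c1ccccc1OC`: 3100 nM

Among the compounds with values here, in a functional assay on MCF7 cells (Homo sapiens) for cytotoxicity, read by CCK-8 assay, with a stated time of 72 h (a lower number here means a stronger inhibitor, a higher number a weaker inhibitor), compound 3 gives 3100 nM, and this is the only number in the set. Compound 1 is recorded as "not active" (no number reported) and compound 2 as "not active" (no number reported), with no number in either case, so neither can be placed against compound 3 on a scale. Within the data shown here, compound 3 therefore stands alone as the single quantified point, and no step between measured compounds is available.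

Compound 4 `C=CCn1c(=O)/c(=C\c2cccc(Cl)c2)[nH]c(=O)/c1=C\c1ccccc1OC` is the next entry and differs from compound 3 in one place: 3-chlorophenyl in place of 5-fluoro-2-methylphenyl on a double-bonded chain carbon bound to an aromatic carbon. Among the measured compounds shown here, with no measured step to lean on, the direction of this change cannot be read from the data; compound 2, which also carries a chlorine-bearing ring on that arm, gives no number, but it differs from compound 4 elsewhere as well and so settles nothing. The step of a 1.6-fold higher number from compound 3 to compound 4 (0.21 log units; within the scatter) is expected to be modest, if anything toward a weaker inhibitor, and quite possibly within the scatter. Compound 4 is estimated at 5000 nM in this assay, with a range from 1500 nM to 20000 nM.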

Compound 4, half-maximal inhibitory concentration: 5200 nM
Compound 4: middle estimate off by 1.0-fold (0.02 log units), on the low side; low and high end bracket the measured number.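

In this assay, within the data shown here, 3-chlorophenyl in place of 5-fluoro-2-methylphenyl on a double-bonded chain carbon bound to an aromatic carbon gives a 1.7-fold higher number from compound 3 to compound 4 (0.22 log units; within the scatter), the first step that can be read at all. This position therefore accepts an exchange of one substituted phenyl for another, with a different count and kind of ring substituents, without a change that can be told from the usual scatter, and a second number now exists where compound 3 previously stood alone. No measurement shown here offers a reason for this result, and a single step within the scatter does not separate the two rings.

Among these compounds, the entries for compound 1 and compound 2 carry no number, so no steps involving them can be read, and it remains open what separates them from the two quantified compounds. Also open, on these data alone, is whether any group at this position can move the number beyond the scatter in either direction, for example a phenyl ring bearing a carboxylic acid or a dimethylamino group, or a longer chain between the ring and the double-bonded carbon.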